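Replacing 4-methoxyphenyl with 3-bromo-4-hydroxyphenyl

This account rests on a few compounds, and the source may have more. Where it says the series, first, only, none or still open, it means among the compounds named here.

Compound 1 `O=C(N/N=C/c1ccc(O)cc1)Nc1ccc(Oc2ccnc3[nH]ccc23)c(F)c1`: 3760 nM
Compound 2 `COc1ccc(/C=N/NC(=O)Nc2ccc(Oc3ccnc4[nH]ccc34)c(F)c2)cc1`: 3980 nM

In a functional assay on A549 cells (Homo sapiens) for antiproliferative activity, read by MTT assay, with a stated time of 72 h (a higher number here means a weaker inhibitor, a lower number a stronger inhibitor), compound 2 gives 3980 nM, the higher number of the pair but within the scatter of compound 1. Compound 3 `O=C(N/N=C/c1ccc(O)c(Br)c1)Nc1ccc(Oc2ccnc3[nH]ccc23)c(F)c1` differs from compound 2 as follows: 3-bromo-4-hydroxyphenyl in place of 4-methoxyphenyl on a carbon with a double bond to nitrogen. Among the compounds with values here, the one measured step bearing on this change is a 1.1-fold higher number from compound 1 to compound 2 (0.02 log units; within the scatter), and it stayed within the scatter. Within the data shown here, it covers the methyl on the oxygen only, and no measured step covers the bromine. No step beyond the scatter is therefore expected, though with real uncertainty. The expected step is a 1.2-fold lower number from compound 2 to compound 3 (0.09 log units; within the scatter). For compound 3 the estimated value is 3200 nM, with an expected range of 1200 nM to 8000 nM.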

Compound 3, half-maximal inhibitory concentration: 9250 nM
For compound 3 the middle estimate is 2.9-fold (0.46 log units) below the measured one; measured number above the stated range.
By their numbers in this assay, from the lowest: compounds 1 and 2 (each within the scatter of the next); then compound 3.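

In this assay bromo in place of hydrogen on an aromatic carbon gives a 2.5-fold higher number from compound 1 to compound 3 (0.39 log units; beyond the scatter) and so moves the number beyond the scatter, which the methyl on the oxygen did not do. The whole exchange of 4-methoxyphenyl for 3-bromo-4-hydroxyphenyl gives a 2.3-fold higher number from compound 2 to compound 3 (0.37 log units; beyond the scatter) and shows that, of the changes at this position, only those that bring in the bromine go beyond the scatter.

As far as these compounds go, whether a chloro group or a methyl group in place of the bromine would give a step of this kind stays open. Nothing given here explains the rise.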